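A few compounds are considered here, and "the series" means these few. Any claim that something is new, unique, unknown or untested is made for them only; others in the source may bear on it.

In a physicochemical assay for solubility, with a stated time of 24 h, at pH 4.5 (on this read-out lower numbers stand for lower solubility and higher numbers for higher solubility), compound 1 `O=C(NC[C@@H]1[C@H]2CN(C(=O)/C=C/c3cc(Cl)cc(Cl)c3)C[C@@H]12)c1ccc2[nH]c(=O)oc2c1` gives < 1 ug/mL, which is a limit and not a number. Compound 2 `O=C(NC[C@@H]1[C@H]2CN(C(=O)C3CC3c3cc(Cl)cc(Cl)c3)C[C@@H]12)c1ccc2[nH]c(=O)oc2c1` gives < 1 ug/mL, likewise a limit. Both compounds therefore sit together, and the evidence so far is the limit of < 1 ug/mL in this assay, at which 2 of the 2 values shown sit. Compound 3 `CC(OC(=O)N1C[C@@H]2[C@@H](CNC(=O)c3ccc4[nH]c(=O)oc4c3)[C@@H]2C1)c1cc(Cl)cc(Cl)c1` differs from compound 2 by a group of 11 heavy atoms (8 carbon, 1 oxygen, 2 chlorine; one six-membered aromatic ring of carbon only) in place of a group of 11 heavy atoms (9 carbon, 2 chlorine; one three-membered non-aromatic ring of carbon only, one six-membered aromatic ring of carbon only), on a carbonyl carbon, on a carbonyl carbon whose other neighbours are: amide-type nitrogen in a ring. Among the measured compounds shown here, the one measured step, a step that the two limits leave unreadable from compound 1 to compound 2, also falls on a carbonyl carbon but offers no size to carry over, so no step beyond the scatter is expected in this assay, and no direction can be assigned. The expected step is a number no lower from compound 2 to compound 3 (the limit leaves the size open). Another report as a limit is the likelier outcome. For compound 3 the estimate is 1 ug/mL, with an expected range of 0.4 ug/mL to 3 ug/mL.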

Compound 3, solubility: < 1 ug/mL
Compound 3: only a limit was reported (the forecaster's own chance of this, stated with the estimate: 70%); the middle value lies on the limit itself.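

In this assay, among the compounds shown here, compound 1, compound 2 and compound 3 are each reported only as a limit, so no step among them can be read. The compounds shown leave open the actual solubility of each and whether the group changes on the carbonyl carbon alter it.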